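A few compounds are considered here, and "the series" means these few. Any claim that something is new, unique, unknown or untested is made for them only; others in the source may bear on it.

Measured compounds:
- compound 1, `Cc1cccc(NC(=O)[C@H]2CN(C)C[C@@H]2c2ccc(/C=C/C(=O)Nc3ccccc3N)cc2)c1` — 14 mL/min/kg
- compound 2, `CN1C[C@H](C(=O)Nc2ccc(F)c(Br)c2)[C@@H](c2ccc(/C=C/C(=O)Nc3ccccc3N)cc2)C1` — 15 mL/min/kg

In an in vitro ADME assay on microsomes from liver (Homo sapiens) for pharmacokinetics, read by LC-MS, with a stated time of 10 min, tested at 1 uM (a lower number here means slower removal, a higher number faster removal of the compound), compound 1 gives 14 mL/min/kg and compound 2 gives 15 mL/min/kg. Compound 2 cannot be separated from compound 1 on these two numbers: the step of a 1.1-fold higher number from compound 1 to compound 2 (0.03 log units; within the scatter) is within the scatter, so both sit in the same place.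

Compound 3, `CN1C[C@H](C(=O)Nc2cccnc2)[C@@H](c2ccc(/C=C/C(=O)Nc3ccccc3N)cc2)C1`, differs from compound 2 by pyridin-3-yl in place of 3-bromo-4-fluorophenyl on an amide-type nitrogen.

Among the measured compounds shown here, the one measured step that touches the same amide-type nitrogen, a 1.1-fold higher number from compound 1 to compound 2 (0.03 log units; within the scatter), swapped one carbon-only aromatic ring for another and moved the number by less than the scatter. For the measured compounds named here, no measured step exchanges a carbon-only ring for a ring with a hetero atom on this nitrogen, so the expectation for compound 3 leans on compound 2 alone, with a wide range. The expected step is no change at the digits printed from compound 2 to compound 3 (within the scatter), nothing beyond the scatter in either direction. Compound 3 is estimated at 15 mL/min/kg, between 8 mL/min/kg and 30 mL/min/kg.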

Compound 3, clearance: 10 mL/min/kg
Estimate against measurement, compound 3: 1.5-fold (0.18 log units) above, within the range that was stated.
By their numbers in this assay, from the lowest: compounds 3, 1 and 2 (each within the scatter of the next).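

In this assay, the amide-type nitrogen now carries a six-membered aromatic ring with a hetero atom rather than one of carbon only, and the result is a 1.5-fold lower number from compound 2 to compound 3 (0.18 log units; within the scatter). Against the other carbon-only ring the result is a 1.4-fold lower number from compound 1 to compound 3 (0.15 log units; within the scatter), so 3-methylphenyl, 3-bromo-4-fluorophenyl and pyridin-3-yl cannot be told apart at this position, even though pyridin-3-yl brings a hydrogen-bond acceptor and carries no halogen. No measurement available here bears on the reason for these readings.

Still open, as far as these compounds go, is whether anything other than a six-membered aromatic ring on this nitrogen, such as a longer alkyl chain or a chain ending in an amine or a carboxylic acid, would give a step beyond the scatter. Also open, from the compounds shown here alone, is how pyridin-2-yl or pyridin-4-yl would read here.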